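Methyl on the Ring Nitrogen of Compound 1

This account rests on a few compounds, and the source may have more. Where it says the series, first, only, none or still open, it means among the compounds named here.

Compound 1 `O=C(Nc1ccc(Oc2ccnc3[nH]ccc23)cc1)c1cc2cccnc2n(-c2ccccc2)c1=O` gives 290 nM in a functional assay on HT-29 cells (Homo sapiens) for antiproliferative activity, read by MTT assay, with a stated time of 72 h (a lower number here means a stronger inhibitor, a higher number a weaker inhibitor), the second highest of the three numbers; compound 2 `O=C(Nc1ccc(Oc2ccnc3[nH]ccc23)cc1)c1cc2cccnc2n(-c2ccc(Br)cc2)c1=O` gives 270 nM and compound 3 `O=C(Nc1ccc(Oc2ccnc3[nH]ccc23)cc1)c1cc2cccnc2n(-c2ccc(F)c(Cl)c2)c1=O` gives 560 nM. Compound 4 `Cn1ccc2c(Oc3ccc(NC(=O)c4cc5cccnc5n(-c5ccccc5)c4=O)cc3)ccnc21` differs from compound 1 by methyl in place of hydrogen on an aromatic nitrogen. Going by the values given here, no measured step touches that nitrogen: a 1.1-fold lower number from compound 1 to compound 2 (0.03 log units; within the scatter) and a 1.9-fold higher number from compound 1 to compound 3 (0.29 log units; within the scatter) alter only the aryl ring on the other aromatic nitrogen, and a 2.1-fold higher number from compound 2 to compound 3 (0.32 log units; beyond the scatter) is modest. Among the compounds with values here, the series thus holds no direct precedent for a methyl in place of this hydrogen, so the expected step of a 1.3-fold higher number from compound 1 to compound 4 (0.12 log units; within the scatter) is set near zero with a wide range around it. Compound 4 is expected at 380 nM, between 100 nM and 1500 nM.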

Compound 4, half-maximal inhibitory concentration: 620 nM
The estimate for compound 4 lay 1.6-fold (0.21 log units) below the measured number; low and high end bracket the measured number.
By their numbers in this assay, from the lowest: compounds 2, 1, 3 and 4 (each within the scatter of the next, the first and the last beyond it).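

The nitrogen of the five-membered aromatic ring now has a reading of its own: methyl in place of hydrogen gives a 2.1-fold higher number from compound 1 to compound 4 (0.33 log units; beyond the scatter) in this assay, a modest weakening. The earlier steps shown here changed only the aryl ring on the other aromatic nitrogen, so this shows that the series responds at this second site as well, and that compound 4 with its methyl still gives 620 nM. No measurement at hand accounts for the step.

As far as these compounds go, whether a longer chain such as ethyl, or a 2-hydroxyethyl group, would weaken activity further remains open. So does whether methyl has the same effect with the 4-bromophenyl group of compound 2.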